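Replacing difluorophenyl with methylphenyl in compound 2

This account rests on a few compounds, and the source may have more. Where it says the series, first, only, none or still open, it means among the compounds named here.

Compound 2 `O=C(c1ccc(-c2nc(-c3ccc(F)cc3F)no2)s1)C(F)(F)F` holds the highest number of the two measured compounds in an assay on isolated protein for inhibition of protein deacetylase HDAC6 (Homo sapiens) (on this read-out lower numbers stand for stronger inhibition and higher numbers for weaker inhibition), where compound 2 gives 580 nM. Among the compounds with values here, compound 1 `O=C(c1ccc(-c2nc(Cc3cccs3)no2)s1)C(F)(F)F` in this assay gives 170 nM, and the single measured step, a 3.4-fold higher number from compound 1 to compound 2 (0.53 log units; beyond the scatter), changes the group on the same aromatic carbon that is altered here. Compound 3 `Cc1cccc(-c2noc(-c3ccc(C(=O)C(F)(F)F)s3)n2)c1` is not yet measured; it differs from compound 2 as follows: 3-methylphenyl in place of 2,4-difluorophenyl on an aromatic carbon. Within the data shown here, the measured step exchanged a (thiophen-2-yl)methyl for a 2,4-difluorophenyl and so bears only loosely on a swap between two substituted phenyl groups; no measured pair compares one six-membered aromatic carbon ring with another. The expected step, a 1.3-fold lower number from compound 2 to compound 3 (0.11 log units; within the scatter), is therefore small and of uncertain direction, likely within the scatter. Compound 3 is estimated in this assay at 450 nM, with a range from 150 nM to 1300 nM.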

Compound 3, half-maximal inhibitory concentration: 680 nM
Compound 3: middle estimate off by 1.5-fold (0.18 log units), on the low side; measured number inside the range.
By their numbers in this assay, from the lowest: compound 1; then compounds 2 and 3 (each within the scatter of the next).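

In this assay, 3-methylphenyl in place of 2,4-difluorophenyl on this aromatic carbon gives a 1.2-fold higher number from compound 2 to compound 3 (0.07 log units; within the scatter). Within the data shown here, this is the first comparison of one six-membered aromatic carbon ring with another at this position, and the two substituted phenyl groups are not separated by this read-out. The (thiophen-2-yl)methyl group now stands apart from both phenyl groups, with a 4.0-fold higher number from compound 1 to compound 3 (0.60 log units; beyond the scatter) adding to the earlier step; no measurement available here accounts for either step.

As far as these compounds go, whether the lower number of compound 1 belongs to the thiophene ring or to the carbon link that carries it remains open. Also open, from the compounds shown here alone, is whether an unsubstituted phenyl, or an amine or carboxylic acid on the phenyl ring, would move the number at this position, given that the fluorine atoms and the methyl group have so far been compared only with each other.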